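A few compounds are considered here, and "the series" means these few. Any claim that something is new, unique, unknown or untested is made for them only; others in the source may bear on it.

The compounds measured so far, in a functional assay on FM3A cells (Mus musculus) for inhibition; on this read-out higher numbers stand for weaker inhibition and lower numbers for stronger inhibition:

Compound 1, `CCCCNC(=O)OC/C=C(\C)C1=CC(=O)C(C)(C)O1`, gives 7.7 ug/mL.
Compound 2, `C=CCNC(=O)OC/C=C(\C)C1=CC(=O)C(C)(C)O1`, gives 7.6 ug/mL.
Compound 3, `C/C(=C\COC(=O)NC1CCCCC1)C1=CC(=O)C(C)(C)O1`, gives 13 ug/mL.

All three share the same core and differ only in the group on the amide-type nitrogen. The steps to compound 3 are small: a 1.7-fold higher number from compound 1 to compound 3 (0.23 log units; within the scatter) and a 1.7-fold higher number from compound 2 to compound 3 (0.23 log units; within the scatter), both within the scatter, so compound 3 cannot be set apart from compound 1 or compound 2 on these numbers; the three sit together.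

Compound 4, `C/C(=C\COC(=O)Nc1ccccc1)C1=CC(=O)C(C)(C)O1`, differs from compound 3 in one place: phenyl in place of cyclohexyl on an amide-type nitrogen. Among the compounds with values here, no measured pair swaps a saturated ring for an aromatic one; the steps that bear on the change are those at the same nitrogen, a 1.7-fold higher number from compound 1 to compound 3 (0.23 log units; within the scatter) and a 1.7-fold higher number from compound 2 to compound 3 (0.23 log units; within the scatter), which show that butyl, allyl and cyclohexyl there all give numbers within the scatter of one another. On that basis a step from compound 3 to compound 4 is expected to stay within the scatter, with no clear direction, estimated as a 1.1-fold lower number from compound 3 to compound 4 (0.03 log units; within the scatter). Compound 4 is therefore expected to give about 12 ug/mL in this assay, with a range from 5 ug/mL to 30 ug/mL.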

Compound 4, half-maximal inhibitory concentration: > 200 ug/mL
Compound 4 gave a limit, no number; the forecaster's own chance of this, stated with the estimate: 5%; middle value at least 16-fold (1.22 log units) from the limit.
By their numbers in this assay, from the lowest: compounds 2, 1 and 3 (each within the scatter of the next). At a limit, above all of these: compound 4.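

In this assay compound 4 gives > 200 ug/mL which is a limit of the assay and not a number. Butyl, allyl and cyclohexyl on the amide-type nitrogen gave numbers within the scatter of one another, so this position looked undemanding, yet phenyl there gives much weaker inhibition than cyclohexyl (an at least 15-fold higher number from compound 3 to compound 4 (1.18 log units; beyond the scatter)), allyl (an at least 26-fold higher number from compound 2 to compound 4 (1.42 log units; beyond the scatter)) and butyl (an at least 25-fold higher number from compound 1 to compound 4 (1.41 log units; beyond the scatter)). Cyclohexyl and phenyl have the same count of heavy atoms and differ in whether the six-membered ring is aromatic, so at this nitrogen the size of the group by that count does not decide the outcome.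

The compounds shown leave open whether a benzyl group on the same nitrogen would restore inhibition. They also leave open whether a phenyl ring carrying a methoxy group or a chlorine would behave like the plain phenyl.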